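A few compounds are considered here, and "the series" means these few. Any claim that something is new, unique, unknown or untested is made for them only; others in the source may bear on it.

Of the compounds shown here, three built on one shared core have been tested in a functional assay on MCF7 cells (Homo sapiens) for cytotoxicity, read by MTT assay, with a stated time of 72 h; on this read-out higher numbers stand for weaker inhibition and lower numbers for stronger inhibition. Compound 1 `O=C(Nc1ccc(Oc2ccnc3[nH]ccc23)c(F)c1)c1nn(-c2ccc(Br)cc2)ccc1=O` gives 11600 nM. Compound 2 `O=C(Nc1ccc(Oc2ccnc3[nH]ccc23)c(F)c1)c1nn(-c2ccccc2)ccc1=O` gives 34900 nM. Compound 3 `O=C(Nc1ccc(Oc2ccnc3[nH]ccc23)c(F)c1)c1nn(-c2ccc(Cl)c(F)c2)ccc1=O` gives 11600 nM, level with compound 1 and together with it the lowest of the three numbers. Compound 4 `O=C(Nc1ccc(Oc2ccnc3[nH]ccc23)c(F)c1)c1nn(-c2ccc(Cl)c(C(F)(F)F)c2)ccc1=O` differs from compound 3 by trifluoromethyl in place of fluoro on an aromatic carbon. For the measured compounds named here, two measured steps bear on this: a 3.0-fold higher number from compound 1 to compound 2 (0.48 log units; beyond the scatter) and a 3.0-fold lower number from compound 2 to compound 3 (0.48 log units; beyond the scatter), so a substituted phenyl on the aromatic nitrogen gives lower numbers than a bare one, whereas no change at the digits printed from compound 1 to compound 3 (within the scatter), so exchanging one substituent pattern for another has not moved the number. In this assay the step expected from this change is therefore a 1.3-fold lower number from compound 3 to compound 4 (0.11 log units; within the scatter). The estimate for compound 4 is 9000 nM, within 3000 nM to 25000 nM.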

Compound 4, half-maximal inhibitory concentration: 11600 nM
Compound 4: the middle estimate sits 1.3-fold (0.11 log units) below what was measured; low and high end bracket the measured number.
By their numbers in this assay, from the lowest: compounds 1, 3 and 4 (each within the scatter of the next); then compound 2.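

In this assay the swap of fluoro for trifluoromethyl gives no change at the digits printed from compound 3 to compound 4 (within the scatter) even though the entering group has 4 heavy atoms against 1, so at this position the larger group leaves the number where it was. Compound 4 also shows a 3.0-fold lower number from compound 2 to compound 4 (0.48 log units; beyond the scatter) and no change at the digits printed from compound 1 to compound 4 (within the scatter) and so joins the two other substituted phenyl compounds, with bare phenyl compound 2 alone apart. Nothing measured here explains this.

Every substituent on this ring so far contains halogen. As far as these compounds go, whether an amine, a carboxylic acid or a longer chain at this position would shift the number remains open.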